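The source may hold more compounds than are shown below. What is called first, only, known or untested is meant among the compounds shown, and "the series" means these compounds.

Measured compounds:
Compound 1, `CCOc1ccc(-c2nc(OC)c(NC(CC)CC)nc2C)c(Cl)c1`: in an assay on IMR-32 cells for displacement of a labelled ligand from corticotropin-releasing factor receptor 1 (Homo sapiens), read by scintillation counting, with a stated time of 2 h (a lower number here means a stronger inhibitor, a higher number a weaker inhibitor), compound 1 gives 5.9 nM
Compound 2, `CCc1nc(NC(CC)CC)c(OC)nc1-c1ccc(Cl)cc1Cl`: in this assay compound 2 gives 5.9 nM

Both compounds share one core and differ in the groups carried on its rings. On the numbers at hand, compound 2 stands level with compound 1: the two values agree at the digits reported, and the gap between them lies within the ordinary scatter of repeated measurements. No comparison between them is drawn beyond that.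

Compound 3, `CCC(CC)Nc1nc(C)c(-c2ccc(Cl)cc2Cl)nc1OC`, has not yet been measured. It is reached from compound 2 by a single change, (hydrogen in place of methyl on a saturated chain carbon bound to an aromatic carbon). Seen one bond further out, the change reads ethyl to methyl. Compound 1 already carries a methyl at the same position while matching the potency of compound 2, so the step from compound 2 to compound 3 is expected to be none beyond the scatter, estimated as a 1.0-fold higher number from compound 2 to compound 3 (0.01 log units; within the scatter). For compound 3 in this assay the expected value is 6 nM, within a range of 2 nM to 20 nM.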

Compound 3, inhibition constant: 4.3 nM
Beside the measured number, compound 3's estimate is 1.4-fold (0.14 log units) above it, and the stated range covers the measured number.
By their numbers in this assay, from the lowest: compounds 3, 1 and 2 (each within the scatter of the next).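

In this assay, cutting the ethyl down to methyl gives a 1.4-fold lower number from compound 2 to compound 3 (0.14 log units; within the scatter) and so removes one carbon from this position with no change beyond the scatter. For the compounds shown here, compound 3 also gives a first reading of a change on the aromatic ring, with chloro in place of ethoxy on an aromatic carbon giving a 1.4-fold lower number from compound 1 to compound 3 (0.14 log units; within the scatter) and again nothing beyond the scatter. No measurement here bears on the reason for either result.

The compounds shown leave open how a longer chain such as propyl, or a bare hydrogen on that aromatic carbon in place of the whole methyl, would read in this assay. They also leave open whether an amine or a carboxylic acid in place of the chloro would keep the number within the scatter.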